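The source may report more compounds than this note shows. Statements on the series, on what has been measured and on what is new or still open speak of the compounds shown alone.

Three compounds have been measured in an assay on cells for displacement of a labelled ligand from adenosine receptor A2b (Homo sapiens), read by scintillation counting and radioligand binding, with a stated time of 30 min, tested at 10 uM; a lower number here means less inhibition, a higher number more inhibition at the concentration tested (going by the name of the read-out):

Compound 1 `Cn1cnc2c(N3CCCCC3)nc(-c3ccccc3O)nc21`: 30.2%
Compound 2 `CN1CCN(c2nc(-c3ccc(Cl)cc3)nc3[nH]cnc23)CC1`: 6.2%
Compound 3 `Oc1cccc(-c2nc(N3CCCCC3)c3nc[nH]c3n2)c1`: a limit of the assay, > 80%

Of the two plain numbers, compound 2 stands lowest, with compound 1 a step above it that goes beyond the usual scatter. For compound 3 the assay reports only a limit, not a number.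

Compound 4 `CN1CCN(c2nc(-c3cccc(Cl)c3)nc3[nH]cnc23)CC1` is not yet measured. It differs from compound 2 by 3-chlorophenyl in place of 4-chlorophenyl on an aromatic carbon. For the measured compounds named here, no measured pair differs by this single change, so its size cannot be read from the data; in this assay a small rise is expected, possibly within the scatter. Compound 4 is estimated at 15%, between 0% and 45%. The expected step is a number 8.8 percentage points higher from compound 2 to compound 4 (within the scatter).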

Compound 4, a percentage reported as inhibition, at one concentration (the size of the read-out at that concentration, not a potency): 29.9%
The estimate for compound 4 lay 14.9 percentage points below the measured number, and the stated range covers the measured number.
By their numbers in this assay, from the lowest: compound 2; then compounds 4 and 1 (each within the scatter of the next). At a limit, above all of these: compound 3.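

Replacing 4-chlorophenyl with 3-chlorophenyl keeps the same atoms but joins them differently, and it gives a number 23.7 percentage points higher from compound 2 to compound 4 (beyond the scatter) in this assay as the result. So on this aromatic carbon, where the chlorine sits on the phenyl ring makes a real difference to the read-out. No earlier pair could show this, and nothing measured here explains why the shift matters.

From the compounds shown here alone, it remains open how the read-out would respond if an amine or a methoxy group took the place of the chlorine on the phenyl ring.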